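Combretastatin-type stilbenes with amine side chains on HeLa cells

The compounds below may be only part of what the source reports. "The series", "measured", "known", "first", "only" and "open" are said of these compounds alone.

Compound 1 `COc1ccc(/C=C\c2cc(OC)c(OC)c(OC)c2)cc1OCc1ccc(CN[C@H](C(=O)O)[C@H](C)O)cc1`: > 10000 nM
Compound 2 `COc1ccc(/C=C\c2cc(OC)c(OC)c(OC)c2)cc1OCc1ccc(CN2C[C@H](O)C[C@@H]2C(=O)O)cc1`: > 10000 nM
Compound 3 `COc1ccc(/C=C\c2cc(OC)c(OC)c(OC)c2)cc1OCc1ccc(CN2CC[C@@H](O)C2)cc1`: > 10000 nM

In a functional assay on HeLa cells (Homo sapiens) for antiproliferative activity, read by CCK-8 assay, with a stated time of 48 h (a higher number here means a weaker inhibitor, a lower number a stronger inhibitor), compound 3 gives only a limit, > 10000 nM. Compound 1 likewise reaches only a limit, > 10000 nM. Compound 2 also stops at a limit, > 10000 nM. Accordingly (the limit of > 10000 nM in this assay, at which 3 of the 3 values shown sit), and the steps a step that the two limits leave unreadable from compound 1 to compound 2, a step that the two limits leave unreadable from compound 1 to compound 3 and a step that the two limits leave unreadable from compound 2 to compound 3 give no readable size.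

Compound 4 `COc1ccc(/C=C\c2cc(OC)c(OC)c(OC)c2)cc1OCc1ccc(CN2CCCCC2C(=O)NCCN)cc1` differs from compound 3 as follows: 2-((2-aminoethyl)carbamoyl)piperidin-1-yl in place of 3-hydroxypyrrolidin-1-yl on a saturated chain carbon bound to an aromatic carbon. Among the compounds with values here, none of the measured steps bears on this change with a readable size, so no direction beyond the scatter can be expected for compound 4 in this assay, and the estimated step is a step that the limit leaves unreadable from compound 3 to compound 4. Compound 4 is therefore expected to give about 12000 nM, within 2500 nM to 40000 nM.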

Compound 4, half-maximal inhibitory concentration: 7300 nM
Estimate against measurement, compound 4: 1.6-fold (0.22 log units) above; the measured number falls inside the stated range.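

In this assay, compound 4 is the only compound shown that gives a number and not a limit, so 2-((2-aminoethyl)carbamoyl)piperidin-1-yl on this saturated chain carbon gives the first readable value. The change reads as an at least 1.3-fold lower number from compound 3 to compound 4 (0.13 log units; that floor lies within the scatter), as an at least 1.3-fold lower number from compound 2 to compound 4 (0.13 log units; that floor lies within the scatter) and as an at least 1.3-fold lower number from compound 1 to compound 4 (0.13 log units; that floor lies within the scatter). Each of these is only a floor, and the true size of the step stays unknown: the limit of > 10000 nM in this assay, at which 3 of the 4 values shown sit.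

As far as these compounds go, it remains open whether the 2-aminoethyl chain or the piperidine ring accounts for the value. A plain piperidin-1-yl group or a 3-aminopropyl amide at this place would separate the two.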